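Swapping halogens on the phenylpiperazine tail: compound 4

The source may hold more compounds than are shown below. What is called first, only, known or untested is meant among the compounds shown, and "the series" means these compounds.

Measured compounds:
- compound 1, `CC1(c2ccccc2)CC(=O)N(CC(=O)N2CCN(c3ccc(Cl)cc3)CC2)C1=O`: 300 mg/kg
- compound 2, `CC1(c2ccccc2)CC(=O)N(CC(=O)N2CCN(c3ccccc3Cl)CC2)C1=O`: "not active" (no number reported)
- compound 3, `CC1(c2ccccc2)CC(=O)N(CC(=O)N2CCN(c3cccc(Cl)c3Cl)CC2)C1=O`: 300 mg/kg

The three measured compounds share one core and differ only in the chlorinated phenyl group attached to the ring nitrogen of the piperazine. In a functional assay on the whole organism (strain CD-1) with Mus musculus as the target, with a stated time of 0.5 h (on this read-out lower numbers stand for an effect already at smaller amounts and higher numbers for an effect only at larger amounts of compound), compound 1 gives 300 mg/kg. Compound 2 is reported as "not active" (no number reported), with no number attached. Compound 3 gives 300 mg/kg, so it stands level with compound 1; the step of no change at the digits printed from compound 1 to compound 3 (within the scatter), replacing 4-chlorophenyl with 2,3-dichlorophenyl, changed nothing beyond the scatter.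

The next compound, compound 4, `CC1(c2ccccc2)CC(=O)N(CC(=O)N2CCN(c3ccc(F)cc3)CC2)C1=O`, has not yet been measured. The change from compound 3 is 4-fluorophenyl in place of 2,3-dichlorophenyl on an amine nitrogen in a ring

Among the measured compounds shown here, only one measured step bears on this: from compound 1 to compound 3, where no change at the digits printed from compound 1 to compound 3 (within the scatter) left the read-out unchanged while the halogen pattern on the phenyl ring was altered. Compound 2 shows that not every pattern keeps activity, but gives no number to weigh. Given the flat step, compound 4 is expected to stay near compound 3, a step of no change at the digits printed from compound 3 to compound 4 (within the scatter) expected. The estimate for compound 4 in this assay is 300 mg/kg, expected to fall between 100 mg/kg and 600 mg/kg.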

Compound 4, minimum effective dose: "not active" (no number reported)
For compound 4 the study gives words and no number, and the estimate cannot be compared.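

Among the compounds shown here, compound 4, like compound 2, is reported in this assay in words alone, so no step from compound 3 to compound 4 can be read. Nothing in the data shown accounts for this result. The compounds shown leave open what separates compound 1 and compound 3, which carry numbers, from compound 2 and compound 4.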